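Furan in Place of Thiophene on the Sulfonyl Sulfur

The source may hold more compounds than are shown below. What is called first, only, known or untested is meant among the compounds shown, and "the series" means these compounds.

Measured so far:
compound 1 `CNCc1cc(-c2cccnc2F)n(S(=O)(=O)c2cccc(OC)c2)c1`: 92%
compound 2 `CNCc1cc(-c2cccnc2F)n(S(=O)(=O)c2ccsc2)c1`: 98%

In a functional assay on the whole organism (strain Jcl:SD) for inhibition, with Rattus norvegicus as the target, with stated times of 3 min and 3 h, at a dose of 1 mg/kg by the intravenous route (a higher number here means more inhibition at the dose given (going by the name of the read-out), a lower number less inhibition), compound 2 stands highest of the two numbers, and its nearest neighbour is compound 1, the step of a number 6 percentage points higher from compound 1 to compound 2 (within the scatter) lying within the scatter. Compound 3 `CNCc1cc(-c2cccnc2F)n(S(=O)(=O)c2ccoc2)c1` differs from compound 2 by furan-3-yl in place of thiophen-3-yl on a sulfonyl sulfur. Among the measured compounds shown here, the one measured step also exchanged the group on the sulfonyl sulfur and stayed within the scatter, so no step beyond the scatter is expected here: a number 4 percentage points lower from compound 2 to compound 3 (within the scatter). Compound 3 is therefore estimated at 94%, with a range from 82% to 100%.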

Compound 3, a percentage reported as inhibition, in the whole organism at one dose (the size of the read-out at that dose, not a potency): 82%
For compound 3 the middle estimate is 12 percentage points above the measured one, within the range that was stated.
By their numbers in this assay, from the lowest: compounds 3, 1 and 2 (each within the scatter of the next, the first and the last beyond it).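

Among the compounds shown here, on the sulfonyl sulfur, exchanging one five-membered aromatic ring for another with the same heavy-atom count, sulfur giving way to oxygen, produces the first step beyond the scatter in this assay, namely a number 16 percentage points lower from compound 2 to compound 3 (beyond the scatter). This position therefore responds to a single ring atom, while the larger exchange, a number 10 percentage points lower from compound 1 to compound 3 (within the scatter), stays within the scatter. Nothing shown here explains this difference. Open, from the compounds shown here alone, is whether a pyridin-3-yl or thiophen-2-yl ring on the sulfonyl sulfur would match compound 2 or compound 3.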